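A Geometric Isomer Pair in Hepatoma Cytotoxicity Testing

This account rests on a few compounds, and the source may have more. Where it says the series, first, only, none or still open, it means among the compounds named here.

In an ADME assay on HepG2 2.2.15 cells (Homo sapiens) for cytotoxicity, read by MTT assay, with a stated time of 72 h (on this read-out lower numbers stand for higher toxicity in this test and higher numbers for lower toxicity in this test), three compounds have so far been measured. Compound 1 `O=C(OCc1cccc2c1CCOC2=O)c1cc(=O)c2ccccc2o1` gives 2570000 nM in this assay, and compound 2 `N=C(N)c1cccc2c1CCOC2=O` gives 2050000 nM. Compound 3 `O=C1OCCc2c(/C=C\c3ccccc3)cccc21` reaches only a limit of this assay, > 2160000 nM, so no number is known for compound 3. This is the limit of > 2160000 nM in this assay, at which 1 of the 3 values shown sits. Compound 3 therefore stands at the edge of what this assay can report, in the region of low toxicity where all three measured compounds sit.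

The step now leads to compound 4 `O=C1OCCc2c(/C=C/c3ccccc3)cccc21`. Compound 4 and compound 3 have the same atoms and bonds and differ only in configuration as drawn: the two compounds have the same atoms and bonds and differ only in configuration as drawn: 1 of 1 stereo elements differ; a double bond is drawn Z in compound 3 and E in compound 4; a double bond is drawn Z in compound 3 and E in compound 4. Within the data shown here, no step between measured compounds is available here, and a change of drawn configuration alone gives no ground to expect a step beyond the scatter in this assay, in either direction. The step from compound 3 to compound 4 is thus expected to be a step that the limit leaves unreadable from compound 3 to compound 4. Compound 4 is expected to give about 2500000 nM in this assay, within a range from 1000000 nM to 6000000 nM, most likely again as a limit rather than a number.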

Compound 4, half-maximal cytotoxic concentration: > 2430000 nM
Compound 4: a limit, no number (the forecaster's own chance of this, stated with the estimate: 70%); the middle value is on the limit's open side.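

Among these compounds, compound 3 and compound 4 each give only a limit in this assay, and no step between them can be read. The compounds shown leave open whether the drawn configuration of the double bond makes any difference in this assay.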